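This account rests on a few compounds, and the source may have more. Where it says the series, first, only, none or still open, it means among the compounds named here.

Compound 1 `CCn1c(=O)c2nc(-c3ccc(S(=O)(=O)O)cc3)[nH]c2n(CC)c1=O`: 755 nM
Compound 2 `Cn1c(=O)c2nc(-c3cccc([N+](=O)[O-])c3)[nH]c2n(C)c1=O`: 50 nM
Compound 3 `Cn1c(=O)c2nc(-c3ccc(Br)cc3)[nH]c2n(C)c1=O`: 0.75 nM

These three compounds share one core and were tested in an assay for binding affinity to adenosine receptor A1 (Bos taurus); a higher number here means a weaker inhibitor, a lower number a stronger inhibitor. Compound 1 stands at the highest of the three numbers, so it is the weakest binder of the set: compound 2 sits at a lower number and compound 3 at a far lower one, both gaps beyond the usual scatter. Compound 4 `CCn1c(=O)c2nc(-c3ccc(S(=O)(=O)NCCN(C)C)cc3)[nH]c2n(CC)c1=O` has not yet been measured. It differs from compound 1 in one place: (2-(dimethylamino)ethyl)amino in place of hydroxy on a sulfonyl sulfur. Within the data shown here, no measured pair shows this same change, so the expectation rests on compound 1 alone. Because compound 1 gives 755 nM, the highest number here, a moderate move toward a lower number is expected: a 7.6-fold lower number from compound 1 to compound 4 (0.88 log units; beyond the scatter). Compound 4 is estimated at 100 nM, with a range from 20 nM to 500 nM.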

Compound 4, half-maximal inhibitory concentration in the adenosine receptor A1 assay: 3.3 nM
The estimate for compound 4 lay 30-fold (1.48 log units) above the measured number, and the stated range ends above it.
By their numbers in the adenosine receptor A1 assay, from the lowest: compound 3; then compound 4; then compound 2; then compound 1.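

On a sulfonyl sulfur, replacing hydroxy with (2-(dimethylamino)ethyl)amino is far from neutral: in the adenosine receptor A1 assay the change gives a 230-fold lower number from compound 1 to compound 4 (2.36 log units; beyond the scatter). So this position, which the earlier compounds did not test on its own, strongly affects the number. In a physicochemical assay for lipophilicity (on this read-out higher numbers stand for higher lipophilicity and lower numbers for lower lipophilicity), compound 1 gives 0.97 and compound 4 gives 2.57, so the same change moves both read-outs. A single pair cannot show which part of the new group matters. A plain methylamino group, or a longer chain ending in a piperidine, could help separate the amide nitrogen's contribution from that of the dimethylamino end.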